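Amino for 2-oxopiperidin-1-yl: rat oral exposure notes

A few compounds are considered here, and "the series" means these few. Any claim that something is new, unique, unknown or untested is made for them only; others in the source may bear on it.

Measured compounds:
- compound 1 `Cc1ccc(-c2cc(Br)ccc2OCc2ccc(F)cc2F)n1-c1cc(C(=O)O)cc(N2CCCCC2=O)c1`: "not determined" (no result reported) in an ADME assay on the whole organism (plasma) for pharmacokinetics, with Rattus norvegicus as the target, at a dose of 3 mg/kg by the oral route; on this read-out higher numbers stand for higher exposure at the dose given and lower numbers for lower exposure
- compound 2 `Cc1ccc(-c2cc(Cl)ccc2OCc2ccccc2)n1-c1cc(Br)cc(C(=O)O)c1`: 100000000 ng.h/mL

Compound 1 stands without a number on this assay: in this assay compound 1 gives "not determined" (no result reported), the measurement was not carried out, so there is no value to place it against. Among the measured compounds shown here, compound 2 is the only compound with a result; in this assay compound 2 gives 100000000 ng.h/mL. Compound 2 differs from compound 1 in several places at once, so its value says nothing about any single change on the shared core.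

Compound 3 `Cc1ccc(-c2cc(Br)ccc2OCc2ccc(F)cc2F)n1-c1cc(N)cc(C(=O)O)c1` is the next compound. The change from compound 1 to compound 3 is amino in place of 2-oxopiperidin-1-yl on an aromatic carbon, meta to a carboxy group and meta to a large group. For the measured compounds named here, no step between two measured compounds covers this change, and compound 1 itself has no number, so no direction or size of step in this assay can be read from the data; any step here is an open guess rather than a supported one.

For compound 3 the exposure in this assay is expected to be about 5000 ng.h/mL, with a range of 500 ng.h/mL to 50000 ng.h/mL.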

Compound 3, area under the concentration-time curve: < 16700000 ng.h/mL
Compound 3: no number, only a limit (the forecaster's own chance of this, stated with the estimate: 10%); the middle value is on the limit's open side.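

In this assay compound 3 gives < 16700000 ng.h/mL, which is a limit and not a number. Among the compounds shown here, with no number for compound 1 either, no step from compound 1 to compound 3 can be read. The compounds shown leave open both the direction and the size of any change in exposure on going from 2-oxopiperidin-1-yl to amino.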